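Dichlorophenyl in Place of Trifluoromethylphenyl: an Expected Shift

The compounds below may be only part of what the source reports. "The series", "measured", "known", "first", "only" and "open" are said of these compounds alone.

Measured so far:
Compound 1, `C/C(=C\C(=O)Nc1ccc2nc(N3CCC(O)(C4CC4)CC3)nc(C)c2c1)c1ccc(Cl)cc1`, gives 532 nM in an assay on CHO-K1 cells for displacement of a labelled ligand from melanin-concentrating hormone receptor 1 (Homo sapiens), read by scintillation proximity assay, with a stated time of 2 h; a higher number here means a weaker inhibitor, a lower number a stronger inhibitor.
Compound 2, `Cc1nc(N2CCC(O)(C3CC3)CC2)nc2ccc(NC(=O)/C=C/c3ccc(C(F)(F)F)cc3)cc12`, gives 232 nM in this assay.

Compound 2 holds the lowest of the two numbers in this assay; its nearest neighbour is compound 1, and the step of a 2.3-fold lower number from compound 1 to compound 2 (0.36 log units; beyond the scatter) is modest but beyond the scatter. That step, however, changes two things at once, the chain and the group on the ring, so it does not isolate either one.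

Compound 3, `Cc1nc(N2CCC(O)(C3CC3)CC2)nc2ccc(NC(=O)/C=C/c3ccc(Cl)cc3Cl)cc12`, differs from compound 2 in one place: 2,4-dichlorophenyl in place of 4-(trifluoromethyl)phenyl on a double-bonded chain carbon bound to a double-bonded chain carbon. For the measured compounds named here, no measured step changes only this group. Going by the values given here, the only related comparison is compound 1, which carries a chlorophenyl ring together with a different chain and gives a somewhat higher number than compound 2, and this cannot be separated into its parts. The expectation for compound 3 is therefore a small shift at most, with a slight lean towards a higher number, expressed as a 1.4-fold higher number from compound 2 to compound 3 (0.14 log units; within the scatter). Compound 3 is estimated at 320 nM in this assay, with a range from 120 nM to 850 nM.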

Compound 3, half-maximal inhibitory concentration: 620 nM
Beside the measured number, compound 3's estimate is 1.9-fold (0.29 log units) below it; the range from low to high includes it.
By their numbers in this assay, from the lowest: compound 2; then compounds 1 and 3 (each within the scatter of the next).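

For the compounds shown here, with compound 3, the group on the chain changes alone for the first time: 2,4-dichlorophenyl in place of 4-(trifluoromethyl)phenyl gives a 2.7-fold higher number from compound 2 to compound 3 (0.43 log units; beyond the scatter) in this assay, so this position does respond to the group it carries, although the step is modest. Read against compound 1, the result is a 1.2-fold higher number from compound 1 to compound 3 (0.07 log units; within the scatter), which lies within the scatter, so 2-(2,4-dichlorophenyl)ethenyl and 2-(4-chlorophenyl)prop-1-en-1-yl cannot be told apart on this carbonyl carbon, and 4-(trifluoromethyl)phenyl remains the group with the lowest number of the three. No evidence from any other kind of measurement bears on this result.

The compounds shown leave open how much of the step belongs to each chlorine, since a 4-chlorophenyl group on the same ethenyl chain would separate them, and whether the extra methyl on the prop-1-en-1-yl chain matters on its own. As far as these compounds go, it also remains open how this position would respond to a ring carrying a methoxy group, a nitrile or an amine in place of these halogen-bearing groups.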